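Removing the benzyl group: what happens to compound 4

The source may report more compounds than this note shows. Statements on the series, on what has been measured and on what is new or still open speak of the compounds shown alone.

Measured compounds and their values:
compound 1 `CN(C)c1c(C#N)c2c(N)ncnc2n1C` 259 nM
compound 2 `Cn1c(NCc2ccccc2)c(C#N)c2c(N)ncnc21` 243 nM
compound 3 `Cn1c(NCc2ccccc2F)c(C#N)c2c(N)ncnc21` 120 nM

In an assay on isolated protein for binding affinity to Leucine-rich repeat serine/threonine-protein kinase 2 variant G2019S (Homo sapiens), read by TR-FRET and LanthaScreen, with a stated time of 2 h (a lower number here means a stronger inhibitor, a higher number a weaker inhibitor), compound 2 gives 243 nM, which puts it second highest of the three numbers. Its nearest neighbour is compound 1, which gives 259 nM, a gap that lies within the scatter, so the two are not separated. Compound 3 stands furthest from it, and the change a 2.0-fold lower number from compound 2 to compound 3 (0.31 log units; beyond the scatter) is modest but beyond the scatter.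

Compound 4 `Cn1c(N)c(C#N)c2c(N)ncnc21` differs from compound 2 by hydrogen in place of benzyl on a nitrogen on an aromatic ring. Going by the values given here, none of the measured steps touches this change: the only step measured, from compound 2 to compound 3, concerns a fluorine on the aromatic ring of the benzyl group, and the pair of compound 1 and compound 2 shows that exchanging a dimethylamino group for a benzylamino group leaves the number within the scatter. There is therefore no measured guide to what the loss of the whole benzyl group does. The benzyl group is a sizeable part of compound 2, and its removal leaves a much smaller molecule, so a somewhat weaker result is expected rather than none. Compound 4 is estimated at 650 nM, with a range from 200 nM to 2500 nM. That estimate means a step of a 2.7-fold higher number from compound 2 to compound 4 (0.43 log units; beyond the scatter), a moderate rise in the number with considerable uncertainty.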

Compound 4, inhibition constant: 589 nM
Beside the measured number, compound 4's estimate is 1.1-fold (0.04 log units) above it; the range from low to high includes it.
By their numbers in this assay, from the lowest: compound 3; then compounds 2 and 1 (each within the scatter of the next); then compound 4.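

In this assay, taking the benzyl group off this nitrogen gives a 2.4-fold higher number from compound 2 to compound 4 (0.38 log units; beyond the scatter), and amino in place of dimethylamino on the same aromatic carbon gives a 2.3-fold higher number from compound 1 to compound 4 (0.36 log units; beyond the scatter), so the position responds to this change, though only modestly. Compounds 1 and 2 had stood within the scatter of each other and so gave no sign of any response here; now both stand beyond the scatter from the unsubstituted amino group of compound 4, which suggests that among these three compounds, having carbon substituents on this nitrogen matters more than which ones they are. The data at hand offer no measured reason for this rise in the number.

Going by these compounds, it remains open whether a single small group, as in a methylamino or a cyclopropylamino compound, would sit with compound 4 or with compounds 1 and 2. Also open, on these data alone, is whether a longer chain such as phenethyl in place of benzyl, or an acetyl group on this nitrogen, would move the number further in either direction.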